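Replacing the dichlorophenyl acyl group in a thiazole hydrazone series

A few compounds are considered here, and "the series" means these few. Any claim that something is new, unique, unknown or untested is made for them only; others in the source may bear on it.

Compound 1 `CN(C(=O)NC(=O)c1ccc(Cl)cc1Cl)c1nc(C(F)(F)F)c(C(=O)N/N=C/c2cccc(C(F)(F)F)c2)s1` gives 10.6 ug/mL in a functional assay on A549 cells (Homo sapiens) for inhibition, read by MTT assay, with a stated time of 72 h; a higher number here means a weaker inhibitor, a lower number a stronger inhibitor.
Compound 2 `CN(C(=O)NC(=O)c1ccc(Cl)cc1Cl)c1nc(C(F)(F)F)c(C(=O)N/N=C/c2ccc(C(F)(F)F)cc2)s1` gives 9.4 ug/mL in this assay.
Compound 3 `CN(C(=O)NC(=O)c1cccc(C(F)(F)F)c1)c1nc(C(F)(F)F)c(C(=O)N/N=C/c2ccccc2C(F)(F)F)s1` gives 12.1 ug/mL in this assay.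

The three numbers lie within the usual scatter of one another; compound 1 sits with compound 2 on one side and compound 3 on the other, and neither gap is beyond the scatter. Going by the values given here, the only step recorded between two compounds that differ in one place is a 1.1-fold lower number from compound 1 to compound 2 (0.05 log units; within the scatter), which alters the ring on the carbon with a double bond to nitrogen and leaves the acyl part of the molecule untouched.

Compound 4 `CN(C(=O)NC(=O)c1c(F)cccc1F)c1nc(C(F)(F)F)c(C(=O)N/N=C/c2cccc(C(F)(F)F)c2)s1` differs from compound 1 by 2,6-difluorophenyl in place of 2,4-dichlorophenyl on a carbonyl carbon. Among the compounds with values here, no measured step changes the group on this carbonyl carbon alone. Compound 3 does carry a different ring there, but it also differs at the hydrazone end, so its value can only be set beside that of compound 1, and the two lie within the scatter. With nothing pointing to a change beyond the scatter, compound 4 is expected to land close to compound 1, giving an estimated no change at the digits printed from compound 1 to compound 4 (within the scatter). The estimate for compound 4 is 10.6 ug/mL, with a range from 5 ug/mL to 22 ug/mL.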

Compound 4, half-maximal inhibitory concentration: 27.6 ug/mL
The estimate for compound 4 lay 2.6-fold (0.42 log units) below the measured number; measured number above the stated range.
By their numbers in this assay, from the lowest: compounds 2, 1 and 3 (each within the scatter of the next); then compound 4.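

The acyl position, on a carbonyl carbon whose other neighbours are an amide-type nitrogen, is not indifferent in this assay: with the rest of compound 1 kept, 2,6-difluorophenyl in place of 2,4-dichlorophenyl gives a 2.6-fold higher number from compound 1 to compound 4 (0.42 log units; beyond the scatter), a modest step but the only one shown that lies beyond the scatter. Going by these compounds alone, the earlier compounds could not show this, as their single recorded step changes the ring at the hydrazone end, while compound 3 carries another ring on this carbonyl carbon but also differs at that end. The two rings match in heavy-atom count and in their lack of hydrogen-bond donors and acceptors, and no measurement at hand accounts for the step.

Both the halogen and its placement on the ring change together from compound 1 to compound 4, so the compounds shown cannot say which of the two matters. They also leave open how an unsubstituted phenyl or a cyclohexyl would read on the same carbonyl carbon, and whether the step would recur with a different ring at the hydrazone end.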